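A New Group on the Carbonyl Carbon of Compound 2

A few compounds are considered here, and "the series" means these few. Any claim that something is new, unique, unknown or untested is made for them only; others in the source may bear on it.

Compound 1 `COc1cc(-c2nn(-c3cccc(NC(=O)Nc4cc(C(F)(F)F)cc(C(F)(F)F)c4)c3)cc2-c2ccncc2)ccc1Cl`: 530 nM
Compound 2 `COc1cc(-c2nn(-c3cccc(NC(=O)Nc4ccc(Cl)c(Cl)c4)c3)cc2-c2ccncc2)ccc1Cl`: 810 nM
Compound 3 `O=C(Nc1cccc(-n2cc(-c3ccncc3)c(-c3ccc(Cl)c(O)c3)n2)c1)Nc1ccc(Cl)c(Cl)c1`: 1010 nM

In a functional assay on KM12 cells (Homo sapiens) for inhibition, read by sulforhodamine B assay, with a stated time of 48 h (a lower number here means a stronger inhibitor, a higher number a weaker inhibitor), compound 1 gives 530 nM, compound 2 gives 810 nM and compound 3 gives 1010 nM. Compound 2 stands second highest of these three numbers; its nearest neighbour is compound 3 and its furthest is compound 1, and both gaps lie within the scatter. Within the data shown here, the only single-point step among the measured compounds, a 1.2-fold higher number from compound 2 to compound 3 (0.10 log units; within the scatter), concerns hydrogen in place of methyl on an oxygen on an aromatic ring and leaves the carbonyl end of the molecule untouched.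

Compound 4 `COc1cc(-c2nn(-c3cccc(NC(=O)c4ccc(Cl)c(C(F)(F)F)c4)c3)cc2-c2ccncc2)ccc1Cl` differs from compound 2 by 4-chloro-3-(trifluoromethyl)phenyl in place of (3,4-dichlorophenyl)amino on a carbonyl carbon. Among the measured compounds shown here, no measured pair shows a change at this carbonyl carbon, so no size of step can be read off for it; the three measured values, all within the scatter of one another, give no ground for expecting a shift beyond the scatter in either direction. Compound 4 is therefore expected to come out at 800 nM, within a range from 250 nM to 2600 nM. This estimate amounts to an expected 1.0-fold lower number from compound 2 to compound 4 (0.01 log units; within the scatter).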

Compound 4, half-maximal inhibitory concentration: 2060 nM
Estimate against measurement, compound 4: 2.6-fold (0.41 log units) below, and the stated range covers the measured number.
By their numbers in this assay, from the lowest: compounds 1, 2 and 3 (each within the scatter of the next); then compound 4.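

In this assay, the carbonyl carbon is a place where a change shows beyond the scatter: 4-chloro-3-(trifluoromethyl)phenyl in place of (3,4-dichlorophenyl)amino gives a 2.5-fold higher number from compound 2 to compound 4 (0.41 log units; beyond the scatter), whereas the earlier single-point step at the oxygen on the aromatic ring, a 1.2-fold higher number from compound 2 to compound 3 (0.10 log units; within the scatter), did not leave the scatter. This one step changes two things together, since the amino nitrogen and its hydrogen-bond donor leave and a trifluoromethyl group enters, so the measured values cannot assign the higher number to either part. No measured information on the cause of this shift is available.

The compounds shown leave open how each part counts alone. A 3,4-dichlorophenyl group attached directly to the carbonyl carbon, or a 4-chloro-3-(trifluoromethyl)phenylamino group at the same place, would separate the two.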